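Working notes: hydroxy in place of hydrogen on compound 3

This account rests on a few compounds, and the source may have more. Where it says the series, first, only, none or still open, it means among the compounds named here.

- compound 1 `COc1ccc(-c2c(-c3cc(OC)c(OC)c(OC)c3)ssc2=S)cc1[N+](=O)[O-]` gives 3550 nM
- compound 2 `COc1ccc(-c2c(-c3cc(OC)c(OC)c(OC)c3)ssc2=O)cc1N` gives > 100000 nM
- compound 3 `COc1ccc(-c2ss/c(=N/O)c2-c2cc(OC)c(OC)c(OC)c2)cc1` gives 6660 nM

Going by the values given here, in a functional assay on HT-1080 cells (Homo sapiens) for antiproliferative activity, read by MTT assay, with a stated time of 72 h (a higher number here means a weaker inhibitor, a lower number a stronger inhibitor), compound 3 stands at 6660 nM and lies within the scatter of compound 1, the only other true number in the set. The reading of compound 2 is a limit and not a number.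

Compound 4 `COc1ccc(-c2ss/c(=N/O)c2-c2cc(OC)c(OC)c(OC)c2)cc1O` differs from compound 3 by hydroxy in place of hydrogen on an aromatic carbon (hydroxy in place of hydrogen on an aromatic carbon, ortho to a methoxy group). Among the compounds with values here, no measured pair gives the size of this change, so only a modest move towards a lower number is expected, with a wide range. The estimated change is a 2.7-fold lower number from compound 3 to compound 4 (0.43 log units; beyond the scatter) (a stronger reading expected). Compound 4 is estimated at 2500 nM (expected range 300 nM to 20000 nM).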

Compound 4, half-maximal inhibitory concentration: 730 nM
Beside the measured number, compound 4's estimate is 3.4-fold (0.53 log units) above it, within the range that was stated.
By their numbers in this assay, from the lowest: compound 4; then compounds 1 and 3 (each within the scatter of the next). At a limit, above all of these: compound 2.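

In this assay, the change from 4-methoxyphenyl to 3-hydroxy-4-methoxyphenyl gives a 9.1-fold lower number from compound 3 to compound 4 (0.96 log units; beyond the scatter), so this aromatic carbon, ortho to a methoxy group, takes a hydroxy with a clear shift to a lower number. Compounds 1 and 2 differ from compound 3 in more than one place, so neither isolated this position. Nothing at hand accounts for the size of the step.

Going by these compounds, whether the shift is particular to hydroxy remains open. A fluorine or a carboxylic acid on the same carbon of the core of compound 3 would test this.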